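The source may hold more compounds than are shown below. What is called first, only, known or untested is meant among the compounds shown, and "the series" means these compounds.

Working notes on the series.

Among the measured compounds shown here, compound 3 `CCCc1nc2ccc(OC3CCN(C(C)=N)CC3)cc2n1Cc1ccc2ccc(C(=N)N)cc2c1` gives 6.8 nM in an assay on isolated protein for inhibition of serine protease 1 (Bos taurus) (on this read-out higher numbers stand for weaker inhibition and lower numbers for stronger inhibition), and stands lowest of the three numbers measured so far. Compound 1 `CCCCc1nc2cc(OC3CCN(C(C)=N)CC3)ccc2n1Cc1ccc2ccc(C(=N)N)cc2c1` gives 14 nM in this assay, and compound 2 `CCc1nc2cc(OC3CCN(C(C)=N)CC3)ccc2n1Cc1ccc2ccc(C(=N)N)cc2c1` gives 17 nM in this assay; both numbers lie beyond the scatter above that of compound 3.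

The next compound, compound 4 `CCCCc1nc2ccc(OC3CCN(C(C)=N)CC3)cc2n1Cc1ccc2ccc(C(=N)N)cc2c1`, differs from compound 3 by methyl in place of hydrogen on a saturated chain carbon, three bonds along the chain from an aromatic carbon, so the chain on the shared core is lengthened from propyl to butyl. For the measured compounds named here, the one measured step that bears on a chain length change of this kind is a 1.2-fold higher number from compound 1 to compound 2 (0.08 log units; within the scatter), which runs the other way, from butyl to ethyl, on the core of compound 1 where the ether sits at a different position, and it stays within the scatter. On that basis no step beyond the scatter is expected from compound 3 to compound 4, which is written as a 1.0-fold higher number from compound 3 to compound 4 (0.01 log units; within the scatter). For compound 4 the expected value in this assay is 7 nM, within a range of 3 nM to 16 nM.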

Compound 4, inhibition constant: 5.7 nM
Compound 4: middle estimate off by 1.2-fold (0.09 log units), on the high side; the range from low to high includes it.
By their numbers in this assay, from the lowest: compounds 4 and 3 (each within the scatter of the next); then compounds 1 and 2 (each within the scatter of the next).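

On the shared core, the change from propyl to butyl gives a 1.2-fold lower number from compound 3 to compound 4 (0.08 log units; within the scatter) in this assay, so methyl in place of hydrogen on a saturated chain carbon, three bonds along the chain from an aromatic carbon, shifts the number by no more than the scatter. The only earlier chain step, a 1.2-fold higher number from compound 1 to compound 2 (0.08 log units; within the scatter), came from the core of compound 1 and likewise stayed within the scatter, so chain length now shows no step beyond the scatter on either core across the pairs shown. Nothing available explains this flat response.

As far as these compounds go, whether it continues to a longer chain such as hexyl remains open. A chain ending in an amine or a carboxylic acid, or a branched chain such as isobutyl, could still move the number on this core.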